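Para-substituted benzylidene ketones: from bromo to methyl

The compounds below may be only part of what the source reports. "The series", "measured", "known", "first", "only" and "open" are said of these compounds alone.

Values so far in a functional assay on CCRF-CEM cells (Homo sapiens) for inhibition; on this read-out higher numbers stand for weaker inhibition and lower numbers for stronger inhibition:
- compound 1 `O=C1CCCCC/C1=C\c1ccccc1` gives 110000 nM
- compound 2 `O=C1CCCCC/C1=C\c1ccc(F)cc1` gives 198000 nM
- compound 3 `O=C1CCCCC/C1=C\c1ccc(Br)cc1` gives 42800 nM

Compound 3 holds the lowest of the three numbers, and its steps to both other compounds lie beyond the scatter. Compound 4 `Cc1ccc(/C=C2\CCCCCC2=O)cc1`, not yet measured, carries methyl in place of bromo on an aromatic carbon.

Among the compounds with values here, no compound with methyl has been measured, so only indirect evidence is available. Bromo in place of hydrogen gave a 2.6-fold lower number from compound 1 to compound 3 (0.41 log units; beyond the scatter), and bromo in place of fluoro gave a 4.6-fold lower number from compound 2 to compound 3 (0.67 log units; beyond the scatter). Both steps are modest. Fluoro in place of hydrogen gave a 1.8-fold higher number from compound 1 to compound 2 (0.26 log units; within the scatter), which stays within the scatter. Compound 4 loses the bromo, so part of the modest gain shown by a 2.6-fold lower number from compound 1 to compound 3 (0.41 log units; beyond the scatter) is expected to be given back, leaving it near the hydrogen parent. In this assay the expected change is a small move to a higher number, a 1.6-fold higher number from compound 3 to compound 4 (0.21 log units; within the scatter), which may not clear the scatter. For compound 4 the estimate is 70000 nM, with an expected range from 30000 nM to 170000 nM.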

Compound 4, half-maximal inhibitory concentration: > 500000 nM
Compound 4 was reported as a limit; the forecaster's own chance of this, stated with the estimate: 5%; middle value at least 7.1-fold (0.85 log units) away from the limit.
By their numbers in this assay, from the lowest: compound 3; then compounds 1 and 2 (each within the scatter of the next). At a limit, above all of these: compound 4.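

In this assay the value of compound 4 is a limit and not a number: the limit of > 500000 nM in this assay, at which 1 of the 4 values shown sits.

Within the data shown here, on an aromatic carbon para to a group of 9 heavy atoms, a change that keeps the heavy-atom count the same, methyl in place of bromo, gives an at least 11-fold higher number from compound 3 to compound 4 (1.06 log units; beyond the scatter), a large step, whereas the steps among the earlier compounds were modest at most. Methyl also stands apart from the other two groups, with an at least 4.5-fold higher number from compound 1 to compound 4 (0.65 log units; beyond the scatter) and an at least 2.5-fold higher number from compound 2 to compound 4 (0.40 log units; beyond the scatter), so replacing hydrogen at this place can move the number in either direction beyond the scatter: down with bromo in compound 3 and up with methyl in compound 4, while fluoro in compound 2 stays within the scatter of compound 1.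

Going by these compounds, the full size of the three steps to compound 4 stays open, since each rests on a limit. On these data alone, whether chloro, methoxy or an ethyl group at the same place would follow bromo or methyl also stays open, as does whether the bromo and methyl difference holds at any other place on the ring.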